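Swapping methyl for chloro on the ester ring of compound 2

A few compounds are considered here, and "the series" means these few. Any claim that something is new, unique, unknown or untested is made for them only; others in the source may bear on it.

Of the compounds shown here, three of one shared core have been tested in a functional assay on U-251 cells (Homo sapiens) for antiproliferative activity, read by sulforhodamine B assay, with a stated time of 48 h, tested at 50 uM; a higher number here means more inhibition at the concentration tested (going by the name of the read-out), a lower number less inhibition. Compound 1, `Cc1cc2c(C(C)C)ccc(C)c2cc1OC(=O)c1cccc(C(F)(F)F)c1`, was reported as "not active" (no number reported). Compound 2, `CC1=CC[C@H](C(C)C)c2cc(C)c(OC(=O)c3cccc(C)c3)cc21`, gives 16.8%. Compound 3, `CC1=CC[C@H](C(C)C)c2cc(C)c(OC(=O)c3ccc(Cl)cc3)cc21`, gives 25.6%. On the numbers shown, compound 2 and compound 3 lie within the scatter of each other, since the step of a number 8.8 percentage points higher from compound 2 to compound 3 (within the scatter) is within the usual spread of repeated measurements, and compound 1 offers no number to compare against.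

Compound 4 is `CC1=CC[C@H](C(C)C)c2cc(C)c(OC(=O)c3cccc(Cl)c3)cc21`. It differs from compound 2 in one place: chloro in place of methyl on an aromatic carbon. Cut one bond further out, this reads as 3-methylphenyl to 3-chlorophenyl.

Within the data shown here, the only measured step that bears on this change is the one from compound 2 to compound 3, where 4-chlorophenyl replaced 3-methylphenyl on the carbonyl carbon and the read-out moved by a number 8.8 percentage points higher from compound 2 to compound 3 (within the scatter), within the scatter. Since that change also brought a chloro onto the ring in place of a methyl, a small shift in this assay is expected for compound 4 as well, in the same direction but not beyond the scatter, giving an expected step of a number 5.2 percentage points higher from compound 2 to compound 4 (within the scatter). Compound 4 is therefore estimated at 22%, within a range from 8% to 38%.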

Compound 4, a percentage reported as inhibition, at one concentration (the size of the read-out at that concentration, not a potency): 0.9%
Estimate against measurement, compound 4: 21.1 percentage points above; the whole stated range lies above it.
By their numbers in this assay, from the lowest: compound 4; then compounds 2 and 3 (each within the scatter of the next).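

At this aromatic carbon, meta to a large group, chloro in place of methyl is not a neutral swap in this assay: the change gives a number 15.9 percentage points lower from compound 2 to compound 4 (beyond the scatter), the first step among these compounds that goes beyond the scatter. Where the chloro sits on the ring also matters, since 3-chlorophenyl in place of 4-chlorophenyl gives a number 24.7 percentage points lower from compound 3 to compound 4 (beyond the scatter), so the same atom on the same ring does not read the same in its two places. Nothing available accounts for either drop.

The compounds shown leave open how an amine or a carboxylic acid would read on this same aromatic carbon, and whether 4-methylphenyl would stand apart from 3-methylphenyl in the way 4-chlorophenyl stands apart from 3-chlorophenyl. From the compounds shown here alone, each number also gives the size of the read-out at a single concentration, so how potent these compounds are remains open, and with it whether the order seen here would hold at other concentrations.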